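The compounds below may be only part of what the source reports. "The series", "measured", "known", "first", "only" and "open" are said of these compounds alone.

For the measured compounds named here, in an ADME assay on PBMC cells (Homo sapiens) for cytotoxicity, with a stated time of 5 days (on this read-out higher numbers stand for weaker inhibition and lower numbers for stronger inhibition), compound 2 `[N-]=[N+]=N[C@H]1C[C@H](n2cnc3c(NC4CC4)nc(Cl)nc32)O[C@@H]1CO` gives 35300 nM, the only number so far. Compound 1 `COc1nc(NC2CC2)c2ncn([C@H]3C[C@H](N=[N+]=[N-])[C@@H](CO)O3)c2n1` reads > 100000 nM, which is a limit. Compound 3 `[N-]=[N+]=N[C@H]1C[C@H](n2cnc3c(NC4CC4)nc(N)nc32)O[C@@H]1CO` reads > 100000 nM, also a limit. The next analogue is compound 4 `COc1nc(Cl)nc2c1ncn2[C@H]1C[C@H](N=[N+]=[N-])[C@@H](CO)O1`, with methoxy in place of cyclopropylamino on an aromatic carbon. The nearest measured steps are an at least 2.8-fold lower number from compound 1 to compound 2 (0.45 log units; beyond the scatter) and an at least 2.8-fold higher number from compound 2 to compound 3 (0.45 log units; beyond the scatter), and both change the group at the chloro carbon instead. Both are bounded by the limit of > 100000 nM in this assay, at which 2 of the 3 values shown sit. Compound 4 keeps the chloro of compound 2 , which gives 35300 nM, so no step beyond the scatter is expected in this assay. The expected step is a 1.1-fold higher number from compound 2 to compound 4 (0.05 log units; within the scatter). For compound 4 the estimate is 40000 nM, with an expected range of 12000 nM to 100000 nM.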

Compound 4, half-maximal inhibitory concentration: > 100000 nM
Compound 4 ended at the assay's limit (the forecaster's own chance of this, stated with the estimate: 30%); middle value at least 2.5-fold (0.39 log units) from the limit.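

Until now only the group on the other carbon had varied; this step shows that the carbon bearing cyclopropylamino also governs the read-out in this assay, with an at least 2.8-fold higher number from compound 2 to compound 4 (0.45 log units; beyond the scatter). Keeping chloro is therefore not enough to hold a measurable value, since only the pairing with cyclopropylamino in compound 2 gives a number here. The reading of compound 4 is a limit, so the true size of the step cannot be read: the limit of > 100000 nM in this assay, at which 3 of the 4 values shown sit.

From the compounds shown here alone, whether a plain amino or an ethylamino group on this carbon, with chloro kept, would give a number stays open. That would show whether the three-membered ring or the amine nitrogen carries the difference.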